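Removing the Amide Methyl from a Weakly Cytotoxic Benzamide

This account rests on a few compounds, and the source may have more. Where it says the series, first, only, none or still open, it means among the compounds named here.

Compound 1, `COc1cc(N(C)C(=O)c2ccccc2)cc(OC)c1OC`, and compound 2, `COc1cc(N(C)C(=O)c2ccc([N+](=O)[O-])cc2)cc(OC)c1OC`, were tested in a functional assay on ONS-76 cells (Homo sapiens) for cytotoxicity, read by MTT assay, with a stated time of 72 h; on this read-out lower numbers stand for stronger inhibition and higher numbers for weaker inhibition. In this assay compound 1 gives >= 125000 nM, a limit of the assay rather than a number. Compound 2 gives >= 125000 nM in this assay, again a limit and not a measured number. The step that the two limits leave unreadable from compound 1 to compound 2, nitro in place of hydrogen on an aromatic carbon, therefore cannot be read. Compound 2 thus stands at the limit of >= 125000 nM in this assay, at which 2 of the 2 values shown sit. Compound 3, `COc1cc(NC(=O)c2ccc([N+](=O)[O-])cc2)cc(OC)c1OC`, differs from compound 2 by hydrogen in place of methyl on an amide-type nitrogen. Among the measured compounds shown here, no measured step changes an amide-type nitrogen, so nothing here tells how large a step to expect in this assay or in which direction. With both measured compounds sitting at the limit, compound 3 is expected to stay near it. The estimate for compound 3 is 125000 nM, within 40000 nM to 400000 nM. The expected step is a number no higher from compound 2 to compound 3 (the limit leaves the size open).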

Compound 3, half-maximal inhibitory concentration: >= 125000 nM
Compound 3 gave a limit, no number; the forecaster's own chance of this, stated with the estimate: 75%; the middle value sits exactly at the limit.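

In this assay, among the compounds shown here, compound 3 gives >= 125000 nM, a limit and not a number, so no step from compound 2 to compound 3 can be read. The compounds shown leave open whether any change to the shared core would give a measurable cytotoxic value.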